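The source may hold more compounds than are shown below. What is called first, only, known or untested is meant among the compounds shown, and "the series" means these compounds.

Measured so far in a functional assay on cells for antagonist activity at C-C chemokine receptor type 4 (Homo sapiens), read by GTPgammaS binding; on this read-out higher numbers stand for weaker inhibition and lower numbers for stronger inhibition:
compound 1, `COc1nn(C)c2ncnc(NS(=O)(=O)c3cccc(Cl)c3Cl)c12`, 63.1 nM;
compound 2, `COc1nn(C(C)C)c2ncnc(NS(=O)(=O)c3cccc(Cl)c3Cl)c12`, 251 nM;
compound 3, `COc1nn(CC(N)=O)c2ncnc(NS(=O)(=O)c3cccc(Cl)c3Cl)c12`, 501 nM.

Compound 3 gives the highest of the three numbers. The value nearest to it belongs to compound 2: a 2.0-fold higher number from compound 2 to compound 3 (0.30 log units; within the scatter). Compound 1 lies further off: a 7.9-fold higher number from compound 1 to compound 3 (0.90 log units; beyond the scatter). Compound 4, `CNC(=O)Cn1nc(OC)c2c(NS(=O)(=O)c3cccc(Cl)c3Cl)ncnc21`, has not yet been measured; it differs from compound 3 by methyl in place of hydrogen on an amide-type nitrogen. For the measured compounds named here, no measured step alters the amide-type nitrogen itself; the steps that bear on it are those that enlarge the group carried by the aromatic nitrogen, a 4.0-fold higher number from compound 1 to compound 2 (0.60 log units; beyond the scatter) and a 7.9-fold higher number from compound 1 to compound 3 (0.90 log units; beyond the scatter). Both of these run towards higher numbers, whereas the remaining step, a 2.0-fold higher number from compound 2 to compound 3 (0.30 log units; within the scatter), stays within the scatter. On that basis a small step towards a higher number, or none beyond the scatter, is expected for compound 4, a 1.4-fold higher number from compound 3 to compound 4 (0.15 log units; within the scatter). Compound 4 is accordingly estimated at 700 nM, with a range from 250 nM to 2000 nM.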

Compound 4, half-maximal inhibitory concentration in the C-C chemokine receptor type 4 assay: 631 nM
Compound 4: middle estimate off by 1.1-fold (0.05 log units), on the high side; measured number inside the range.
By their numbers in the C-C chemokine receptor type 4 assay, from the lowest: compound 1; then compounds 2, 3 and 4 (each within the scatter of the next, the first and the last beyond it).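

In the C-C chemokine receptor type 4 assay compound 3 (501 nM) and compound 4 (631 nM) differ by methyl on the amide-type nitrogen, which leaves the number within the scatter (a 1.3-fold higher number from compound 3 to compound 4 (0.10 log units; within the scatter)), so this nitrogen takes the added methyl without a change that can be told apart from the repeat variation. The gaps to the simpler groups on the aromatic nitrogen are beyond the scatter (a 2.5-fold higher number from compound 2 to compound 4 (0.40 log units; beyond the scatter)) (a 10-fold higher number from compound 1 to compound 4 (1.00 log units; beyond the scatter)), so methylcarbamoyl does not close the distance to the methyl of compound 1. In a physicochemical assay for lipophilicity (a lower number here means a more polar compound, a higher number a more lipophilic compound), compound 3 (1.1) and compound 4 (1.3) also stay within the scatter of each other (a number 0.20 log units higher from compound 3 to compound 4 (within the scatter)), and nothing measured here gives a reason for either result.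

Going by these compounds, whether the amide-type nitrogen would accept anything larger than methyl, such as ethyl or cyclopropyl, remains open. On these data alone, in the C-C chemokine receptor type 4 assay it also remains open how a carboxylic acid or an amine in place of the carbamoyl group would read.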